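A few compounds are considered here, and "the series" means these few. Any claim that something is new, unique, unknown or untested is made for them only; others in the source may bear on it.

Series notes. Compound 1 `CC(=O)Nc1cc(-c2c(Nc3cc[nH]n3)nc3ccccn23)nc(C)n1` and compound 3 `CC(=O)Nc1cc(-c2c(Nc3ccn(C)n3)nc3ccccn23)nc(C)n1` share one core; compound 2 `CC(=O)Nc1cc(-c2c(Nc3cc[nH]n3)nc3cccnn23)nc(C)n1` and the unmeasured compound 4 `CC(=O)Nc1cc(-c2c(Nc3ccn(C)n3)nc3cccnn23)nc(C)n1` share another, and the difference between the two cores is not broken down here. In an in vivo ADME assay on the whole organism for metabolic stability, with Rattus norvegicus as the target, at a dose of 0.5 mg/kg by the intravenous route (on this read-out lower numbers stand for a shorter-lived compound and higher numbers for a longer-lived compound), compound 1 gives 0.52 h, compound 3 gives 0.66 h and compound 2 gives 0.82 h. Within the first core the change methyl in place of hydrogen on an aromatic nitrogen produced a 1.3-fold higher number from compound 1 to compound 3 (0.10 log units; within the scatter). The same change, (methyl in place of hydrogen on an aromatic nitrogen), turns compound 2 into compound 4, and its place is the same in both pairs. For compound 4 in this assay a step like the earlier one is expected, a 1.2-fold higher number from compound 2 to compound 4 (0.09 log units; within the scatter), because compound 2 starts from 0.82 h and the first pair moved by a 1.3-fold higher number from compound 1 to compound 3 (0.10 log units; within the scatter). Compound 4 is therefore estimated at 1 h, with the expected range running from 0.6 h to 1.7 h.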

Compound 4, half-life: 0.39 h
For compound 4 the middle estimate is 2.6-fold (0.41 log units) above the measured one, outside the stated range (below it).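

In this assay the methyl in place of hydrogen on an aromatic nitrogen does not carry over unchanged between the two cores, and the new step reads a 2.1-fold lower number from compound 2 to compound 4 (0.32 log units; beyond the scatter). Set beside the earlier step, it differs in direction and the gap exceeds what scatter alone would give: the same change on two cores in this assay, a 1.3-fold higher number (0.10 log units; within the scatter) from compound 1 to compound 3 and a 2.1-fold lower number (0.32 log units; beyond the scatter) from compound 2 to compound 4, 2.7-fold (0.43 log units) apart, beyond the scatter of two such steps

Going by these compounds alone, with only two pairs, this shows that the step seen on one core cannot be assumed on the other, but not which feature of the cores lies behind the gap, nor how any third core would behave.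

Open, as far as these compounds go, is whether an ethyl group or a longer chain on the same nitrogen would follow the step to compound 3 or the step to compound 4. From the compounds shown here alone, a hydroxyethyl group on that nitrogen is equally open on either core.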